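Compound 3: pyridin-2-yl for 4-methoxyphenyl

The source may report more compounds than this note shows. Statements on the series, on what has been measured and on what is new or still open speak of the compounds shown alone.

Going by the values given here, in an ADME assay on HepG2 cells (Homo sapiens) for cytotoxicity, read by fluorescence and resazurin assay, with a stated time of 24 h (a lower number here means that less compound is tolerated, a higher number that more compound is tolerated), compound 2 (`COc1ccc(-c2nnc(SC3=CS(=O)(=O)c4ccccc43)o2)cc1`) gives 22000 nM and stands within the scatter of compound 1 (`O=S1(=O)C=C(Sc2nnc(-c3ccccc3Cl)o2)c2ccccc21`) at 25000 nM on the only two numbers available so far. Compound 3 (`O=S1(=O)C=C(Sc2nnc(-c3ccccn3)o2)c2ccccc21`) keeps the shared core and differs from compound 2 by pyridin-2-yl in place of 4-methoxyphenyl on an aromatic carbon with pyridin-2-yl in place of 4-methoxyphenyl on an aromatic carbon of the five-membered aromatic ring with 2 nitrogen and 1 oxygen. Among the compounds with values here, one measured step bears on this change: a 1.1-fold lower number from compound 1 to compound 2 (0.06 log units; within the scatter) came from an exchange of 2-chlorophenyl for 4-methoxyphenyl on that same carbon and stayed within the scatter. Within the data shown here, no measured compound carries pyridin-2-yl, so this single step is thin support. On that evidence, no step beyond the scatter is expected in this assay and the estimated change is a 1.0-fold higher number from compound 2 to compound 3 (0.02 log units; within the scatter) in either direction. Compound 3 is estimated at 23000 nM with a range of 11000 nM to 50000 nM expected for it.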

Compound 3, half-maximal cytotoxic concentration: 24000 nM
Estimate against measurement, compound 3: 1.0-fold (0.02 log units) below, and the stated range covers the measured number.
By their numbers in this assay, from the lowest: compounds 2, 3 and 1 (each within the scatter of the next).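

In this assay, going by these compounds alone, the aromatic carbon of the five-membered aromatic ring now carries a six-membered aromatic ring with 1 hetero atom for the first time, and this exchange gives no step beyond the scatter: pyridin-2-yl in place of 4-methoxyphenyl gives a 1.1-fold higher number from compound 2 to compound 3 (0.04 log units; within the scatter) and pyridin-2-yl in place of 2-chlorophenyl gives a 1.0-fold lower number from compound 1 to compound 3 (0.02 log units; within the scatter) on the same carbon. Among compound 1, compound 2 and compound 3, the tolerated concentration therefore shows no dependence on which of these three groups sits at this position, and no compound shown goes against that reading, which covers a ring of carbon only as well as a ring with 1 hetero atom. The compounds shown come with no measurement that would give a cause for this flat result.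

Every group shown at this carbon is a six-membered aromatic ring, so it remains open whether a longer alkyl chain, or a phenyl ring carrying an amine or a carboxylic acid, would give a step beyond the scatter. The shared core is the same in all three compounds, so these numbers say nothing about how far the tolerated concentration depends on that core.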